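A few compounds are considered here, and "the series" means these few. Any claim that something is new, unique, unknown or untested is made for them only; others in the source may bear on it.

Compound 2 `CCCS(=O)(=O)Nc1ccc(F)c(C(=O)c2n[nH]c3ncc(-c4ccc(Cl)cc4Cl)cc23)c1F` gives 22% in an assay for binding affinity to dual specificity mitogen-activated protein kinase kinase 4 (Homo sapiens), read by KINOMEscan, tested at 100 nM (a higher number here means a weaker effect of the compound at the concentration tested, a lower number a stronger effect), which is the higher of the two measured numbers. Within the data shown here, compound 1 `CCCS(=O)(=O)Nc1ccc(F)c(C(=O)c2n[nH]c3ncc(-c4ccccc4O)cc23)c1F` gives 9% in this assay, and the single measured step, a number 13 percentage points higher from compound 1 to compound 2 (beyond the scatter), is the only comparison available. Compound 3 `CCCS(=O)(=O)Nc1ccc(F)c(C(=O)c2n[nH]c3ncc(-c4cccc([N+](=O)[O-])c4)cc23)c1F` has not yet been measured. It differs from compound 2 in one place: 3-nitrophenyl in place of 2,4-dichlorophenyl on an aromatic carbon. Among the measured compounds shown here, no measured step involves a nitrophenyl group, so the step from compound 1 to compound 2 bears on the new change only loosely, showing that the aryl group at this position can shift the read-out by a modest amount. A step of similar or smaller size in either direction is therefore expected, and the estimated step is a number 2 percentage points lower from compound 2 to compound 3 (within the scatter). Compound 3 is expected to give about 20% in this assay, with a range from 6% to 45%.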

Compound 3, a percentage reported as activity, at one concentration (the size of the read-out at that concentration, not a potency): 15%
The estimate for compound 3 lay 5 percentage points above the measured number; low and high end bracket the measured number.
By their numbers in this assay, from the lowest: compounds 1, 3 and 2 (each within the scatter of the next, the first and the last beyond it).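

In this assay the exchange of 2,4-dichlorophenyl for 3-nitrophenyl, which removes both chlorines and brings in a nitro group with two hydrogen-bond acceptors, gives a number 7 percentage points lower from compound 2 to compound 3 (within the scatter) and so does not clearly move the read-out. The exchange of 2-hydroxyphenyl for the same 3-nitrophenyl gives a number 6 percentage points higher from compound 1 to compound 3 (within the scatter) and likewise stays inside the usual variation, so compound 3 cannot be separated from either earlier compound, although those two differ clearly from each other. Nothing measured here explains these numbers.

As far as these compounds go, it remains open whether a phenyl ring bearing an amine or a carboxylic acid would read like these three aryl groups. Also open, from the compounds shown here alone, is whether a saturated ring or a short alkyl chain at this place would keep the read-out in the same range.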